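Aryl terminus variation: notes toward compound 4

The compounds below may be only part of what the source reports. "The series", "measured", "known", "first", "only" and "open" are said of these compounds alone.

Measured so far:
compound 1 `C=C/C=C\[C@H](C)[C@H](OC(N)=O)[C@@H](C)[C@H](O)[C@@H](C)C/C(C)=C\[C@H](C)[C@@H](O)[C@@H](C)/C=C\CCc1ccc(Oc2ccccc2)cc1`, 4000 nM;
compound 2 `C=C/C=C\[C@H](C)[C@H](OC(N)=O)[C@@H](C)[C@H](O)[C@@H](C)C/C(C)=C\[C@H](C)[C@@H](O)[C@@H](C)/C=C\CCc1cccc(F)c1`, 370 nM;
compound 3 `C=C/C=C\[C@H](C)[C@H](OC(N)=O)[C@@H](C)[C@H](O)[C@@H](C)C/C(C)=C\[C@H](C)[C@@H](O)[C@@H](C)/C=C\CCc1ccc(C)c(O)c1`, 770 nM.

The three compounds share one core and differ only in the aromatic group at the end of the chain. In a functional assay on MCF7 cells (Homo sapiens) for cytotoxicity (on this read-out higher numbers stand for weaker inhibition and lower numbers for stronger inhibition), compound 1 gives 4000 nM, compound 2 gives 370 nM and compound 3 gives 770 nM. Compound 3 therefore stands second highest of the three numbers: compound 2 lies nearest, with a lower number, and compound 1 lies furthest, with a higher number, both gaps beyond the scatter.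

Compound 4 `C=C/C=C\[C@H](C)[C@H](OC(N)=O)[C@@H](C)[C@H](O)[C@@H](C)C/C(C)=C\[C@H](C)[C@@H](O)[C@@H](C)/C=C\CCc1cc(F)cc(F)c1` is the next member and has not yet been measured in this assay. It differs from compound 3 in one place: 3,5-difluorophenyl in place of 3-hydroxy-4-methylphenyl on a saturated chain carbon, two bonds along the chain from a double-bonded chain carbon

Among the compounds with values here, only one measured step bears on this change, a 2.1-fold higher number from compound 2 to compound 3 (0.32 log units; beyond the scatter), which went from a fluorophenyl to the hydroxy-methylphenyl group and raised the number modestly. Compound 4 runs the other way, back to a fluorinated ring, with a second fluorine. A modest lowering of the number is therefore expected, a 1.9-fold lower number from compound 3 to compound 4 (0.28 log units; within the scatter), landing near compound 2. Compound 4 is estimated at 400 nM, with a range from 150 nM to 1100 nM.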

Compound 4, half-maximal inhibitory concentration: 600 nM
The estimate for compound 4 lay 1.5-fold (0.18 log units) below the measured number, and the stated range covers the measured number.
By their numbers in this assay, from the lowest: compounds 2, 4 and 3 (each within the scatter of the next, the first and the last beyond it); then compound 1.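

Replacing 3-hydroxy-4-methylphenyl with 3,5-difluorophenyl on the saturated chain carbon gives in this assay a 1.3-fold lower number from compound 3 to compound 4 (0.11 log units; within the scatter) and so leaves the two groups unresolved at this position, even though 3,5-difluorophenyl has no hydrogen-bond donor or acceptor and 3-hydroxy-4-methylphenyl has one of each. Adding fluoro in place of hydrogen on an aromatic carbon gives a 1.6-fold higher number from compound 2 to compound 4 (0.21 log units; within the scatter) and so the second fluorine cannot be separated from the single-fluorine ring of compound 2 in this read-out. Compound 4 therefore sits within the scatter of both neighbours, whereas the earlier 2.1-fold higher number from compound 2 to compound 3 (0.32 log units; beyond the scatter) lies just beyond it, so that small gap gives little basis for assigning a distinct effect to either ring pattern.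

No supporting measurement is available to explain any of these steps. On these data alone, it remains open whether an amine or a carboxylic acid on the aromatic ring, or a longer chain carrying that ring, would move the number in this assay beyond the scatter of compound 2 and compound 4 in either direction.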